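A Second Methoxy on the Aryl Ring of Compound 1

A few compounds are considered here, and "the series" means these few. Any claim that something is new, unique, unknown or untested is made for them only; others in the source may bear on it.

Compound 1, `COc1cccc([C@]2(CO)NC[C@@H](O)[C@@H]2O)c1`: 52000 nM in an assay on isolated protein for inhibition of lysosomal alpha-glucosidase (Rattus norvegicus), read by colorimetric assay; on this read-out higher numbers stand for weaker inhibition and lower numbers for stronger inhibition
Compound 2, `OC[C@@]1(c2cccc(F)c2)NC[C@@H](O)[C@@H]1O`: 216000 nM
Compound 3, `COc1cccc([C@@]2(CO)NC[C@H](O)[C@H]2O)c1`: 108000 nM

Compound 1 stands lowest of the three numbers in this assay. Compound 3 lies nearest, with a 2.1-fold higher number from compound 1 to compound 3 (0.32 log units; beyond the scatter), and compound 2 furthest, with a 4.2-fold higher number from compound 1 to compound 2 (0.62 log units; beyond the scatter). Compound 4, `COc1ccc([C@]2(CO)NC[C@@H](O)[C@@H]2O)cc1OC`, awaits measurement in this assay. It differs from compound 1 by methoxy in place of hydrogen on an aromatic carbon. Neither measured step matches this change closely: one exchanges the group already on the ring, the other turns on (the fact that compounds 1 and 3 differ only in the configuration as drawn). Nothing measured here tracks a group added to the ring. The expected step is modest at most, a 1.3-fold higher number from compound 1 to compound 4 (0.13 log units; within the scatter), tilted toward weaker inhibition. Compound 4 is therefore estimated at 70000 nM, with a range from 25000 nM to 200000 nM in this assay.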

Compound 4, half-maximal inhibitory concentration: 105000 nM
Beside the measured number, compound 4's estimate is 1.5-fold (0.18 log units) below it; the range from low to high includes it.
By their numbers in this assay, from the lowest: compound 1; then compounds 4, 3 and 2 (each within the scatter of the next, the first and the last beyond it).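

Placing methoxy in place of hydrogen on an aromatic carbon, ortho to the methoxy group of compound 1 and para to a group of 9 heavy atoms, gives a 2.0-fold higher number from compound 1 to compound 4 (0.31 log units; beyond the scatter) in this assay. For the compounds shown here, this is the first step here that adds a group to the ring rather than exchanging one, and the addition does not lower the number. Nothing measured here accounts for this step. From the compounds shown here alone, how a hydroxyl, an amine or a carboxylic acid at this position would read stays open. So does whether the same added methoxy would move the number in the same direction on the mirror-image core of compound 3.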